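Swapping the isopropylamino group of compound 3 for hydroxymethyl

This account rests on a few compounds, and the source may have more. Where it says the series, first, only, none or still open, it means among the compounds named here.

In a functional assay on HCT-15 cells (Homo sapiens) for inhibition, read by MTT assay, with a stated time of 72 h (a lower number here means a stronger inhibitor, a higher number a weaker inhibitor), compound 1 `CNCc1c(OC)cc(Oc2cccc(Nc3ccccc3)c2)cc1OC` (8930 nM) and compound 2 `COc1cc(Oc2cccc(Nc3ccccc3)c2)cc(OC)c1CN[C@H](C)c1ccccc1` (7550 nM) have numbers within the scatter of each other. Compound 3 `COc1cc(Oc2cccc(Nc3ccccc3)c2)cc(OC)c1CNC(C)C` has only a limit (> 20000 nM) and no number. Compound 4 `COc1cc(Oc2cccc(Nc3ccccc3)c2)cc(OC)c1CCO` carries hydroxymethyl in place of the isopropylamino of compound 3, on a saturated chain carbon bound to an aromatic carbon (hydroxymethyl in place of isopropylamino on a saturated chain carbon bound to an aromatic carbon). The measured changes on the amine nitrogen are small: a 1.2-fold lower number from compound 1 to compound 2 (0.07 log units; within the scatter) and an at least 2.2-fold higher number from compound 1 to compound 3 (0.35 log units; beyond the scatter) and an at least 2.6-fold higher number from compound 2 to compound 3 (0.42 log units; beyond the scatter) are all that is seen. None of them removes that nitrogen, so they are only a rough guide. In this assay the expected move is a modest one toward a lower number (an at least 1.5-fold lower number from compound 3 to compound 4 (0.18 log units; that floor lies within the scatter)). For compound 4 the estimate is 13000 nM (expected range 6000 nM to 28000 nM).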

Compound 4, half-maximal inhibitory concentration: 12100 nM
Estimate against measurement, compound 4: 1.1-fold (0.03 log units) above, within the range that was stated.
By their numbers in this assay, from the lowest: compounds 2, 1 and 4 (each within the scatter of the next). At a limit, above all of these: compound 3.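

In this assay, the side-chain nitrogen can be replaced without a clear change: compound 4, with hydroxymethyl, reads against the methylamino of compound 1 as a 1.4-fold higher number from compound 1 to compound 4 (0.13 log units; within the scatter) and against the (1-phenylethyl)amino of compound 2 as a 1.6-fold higher number from compound 2 to compound 4 (0.20 log units; within the scatter). Against isopropylamino the step is an at least 1.6-fold lower number from compound 3 to compound 4 (0.21 log units; that floor lies within the scatter). Compound 3 gives only a limit, not a number, so the true size of that step stays unknown: the limit of > 20000 nM in this assay, at which 1 of the 4 values shown sits.

Going by these compounds, how a carboxylic acid, a methyl ether or a longer chain at this place would read in this assay remains open.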